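The source may report more compounds than this note shows. Statements on the series, on what has been measured and on what is new or still open speak of the compounds shown alone.

In a functional assay on A549 cells (Homo sapiens) for cytotoxicity, read by MTT assay, with a stated time of 48 h (on this read-out higher numbers stand for weaker inhibition and lower numbers for stronger inhibition), compound 1, `CC(C)n1c(/C=C2/C(=O)Nc3ccc(Br)cc32)nc2ccccc21`, gives 8630 nM. Compound 2, `CCn1c(/C=C2/C(=O)Nc3ccc(F)cc32)nc2ccccc21`, gives > 50000 nM, which is a limit of the assay and not a number. Compound 3, `CCn1c(/C=C2/C(=O)Nc3ccc(C)cc32)nc2ccccc21`, gives > 50000 nM, which is also a limit. Compound 3 therefore has no number of its own and stands on (the limit of > 50000 nM in this assay, at which 2 of the 3 values shown sit).

The next compound is compound 4, `CCn1c(/C=C2/C(=O)Nc3ccc(Br)cc32)nc2ccccc21`, which has bromo in place of methyl on an aromatic carbon. The group sits on a six-membered aromatic ring of carbon only, part of a fused system of two rings.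

Among the measured compounds shown here, the only measured swap of this kind is a step that the two limits leave unreadable from compound 2 to compound 3, methyl in place of fluoro, so it offers no size to carry over. The better guide is compound 1, which has the same bromo group but isopropyl where compound 4 has ethyl. Compound 1 gives 8630 nM. On that basis, stronger inhibition is expected in this assay, though the chain difference leaves this uncertain. The expected change is an at least 3.1-fold lower number from compound 3 to compound 4 (0.49 log units; beyond the scatter), an estimate resting on a single related compound. For compound 4, the estimated value is 16000 nM, with an expected range of 6000 nM to 50000 nM.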

Compound 4, half-maximal inhibitory concentration: > 50000 nM
Compound 4 gave a limit, no number (the forecaster's own chance of this, stated with the estimate: 35%); at least 3.1-fold (0.49 log units) between middle value and limit.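

In this assay, as far as these compounds go, compound 4 also stands at a limit and not at a number, so bromo on this aromatic carbon does not by itself bring a compound with the ethyl chain into the measurable range: the limit of > 50000 nM in this assay, at which 3 of the 4 values shown sit. The steps among compound 2, compound 3 and compound 4 cannot be read, as each has a limit at both ends, and the order of fluoro, methyl and bromo at this position stays unknown. Among the compounds shown here, the one readable step keeps bromo fixed and shortens isopropyl to ethyl, giving an at least 5.7-fold higher number from compound 1 to compound 4 (0.76 log units; beyond the scatter), so in this pair the measurable value belongs to the compound with the isopropyl chain.

From the compounds shown here alone, whether isopropyl would also bring the fluoro and methyl compounds into the measurable range remains open, as does the effect of a longer chain such as butyl in the same place. Going by these compounds, it is also open how an amine or a methoxy group on the aromatic carbon would behave with either chain.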